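A few compounds are considered here, and "the series" means these few. Any claim that something is new, unique, unknown or untested is made for them only; others in the source may bear on it.

The series shares one core, carried by compound 1 `COc1ccc(-n2ccnc2SCC(=O)Nc2ccccc2C)cc1`, compound 2 `Cc1ccc(-n2ccnc2SCC(=O)Nc2ccccc2Cl)cc1` and compound 3 `Cc1ccc(-n2ccnc2SCC(=O)Nc2ccccc2Br)cc1`, while compound 4 `COc1ccc(-n2ccnc2SCC(=O)Nc2ccccc2Cl)cc1` is not yet measured. In an ADME assay on MT4 cells (Homo sapiens) for cytotoxicity, read by MTT assay (a higher number here means that more compound is tolerated, a lower number that less compound is tolerated), compound 2 gives 33700 nM, which is the lowest of the two numbers recorded. Its neighbour compound 3 gives 39300 nM, and the change from one to the other is a 1.2-fold higher number from compound 2 to compound 3 (0.07 log units; within the scatter), bromo in place of chloro on an aromatic carbon. For compound 1 the result is a limit of the assay rather than a number, > 353000 nM, and this is the only such limit among the three compounds (the limit of > 353000 nM in this assay, at which 1 of the 3 values shown sits).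

The step from compound 2 to compound 4 is methoxy in place of methyl on an aromatic carbon. For the measured compounds named here, no measured pair isolates this change: compound 1 carries the methoxy group but differs from compound 2 in two places, so only its two values can be set side by side, a limit against a number. Going by the values given here, the one measured step, bromo for chloro, stayed within the scatter, so it gives no size for a methoxy exchange. The account therefore expects compound 4 to move toward the limit shown by compound 1 in this assay, a step of a 3.0-fold higher number from compound 2 to compound 4 (0.47 log units; beyond the scatter), and estimates its value as 100000 nM, between 30000 nM and 350000 nM.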

Compound 4, half-maximal cytotoxic concentration: > 334000 nM
Compound 4: no number, only a limit; the forecaster's own chance of this, stated with the estimate: 35%; middle value at least 3.3-fold (0.52 log units) from the limit.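

In this assay, the exchange of methyl for methoxy, on an aromatic carbon para to a large group, now has a size of its own, where compound 1 differed from compound 2 in two places and could isolate nothing: the result is an at least 9.9-fold higher number from compound 2 to compound 4 (0.99 log units; beyond the scatter), with the chloro group held fixed. This single exchange lies beyond the scatter, whereas the only earlier step, a 1.2-fold higher number from compound 2 to compound 3 (0.07 log units; within the scatter), lay within it, so among the compounds shown the 4-methylphenyl to 4-methoxyphenyl change is the first that separates two compounds. On these data alone, what compound 4 gives is a limit of the assay and not a number, so the true size of the step stays open on its upper side: the limit of > 334000 nM in this assay, at which 1 of the 4 values shown sits.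

The step between compound 1 and compound 4, chloro in place of methyl on an aromatic carbon, cannot be read, since both ends are limits. The compounds shown also leave open whether the tolerance follows the oxygen or the longer group, which a hydroxy group, an ethoxy group or an amine at the same carbon would help to separate.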